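Compound 1 to Compound 4: A Ring Swap Awaiting Measurement

A few compounds are considered here, and "the series" means these few. Any claim that something is new, unique, unknown or untested is made for them only; others in the source may bear on it.

Of the compounds shown here, three sharing one core have been tested in a functional assay on MGC-803 cells (Homo sapiens) for antiproliferative activity, read by MTT assay, with a stated time of 72 h; a higher number here means a weaker inhibitor, a lower number a stronger inhibitor. Compound 1, `Cc1ccc(-c2nc(CNc3ccc(C(=O)NO)cc3)n(-c3ccccc3)n2)cc1`, reaches only a limit in this assay, giving > 20000 nM. Compound 2, `O=C(NO)c1ccc(NCc2nc(-c3ccccc3)nn2-c2ccc(F)cc2)cc1`, gives 10500 nM. Compound 3, `COc1ccc(-n2nc(-c3ccc(O)cc3)nc2CNc2ccc(C(=O)NO)cc2)cc1`, likewise reaches only a limit, at > 20000 nM. Compound 1 therefore stands at the limit of > 20000 nM in this assay, at which 2 of the 3 values shown sit, so no number for it is known, and no measured step between any two of these compounds exists. Compound 4, `O=C(NO)c1ccc(NCc2nc(-c3cc4ccccc4s3)nn2-c2ccccc2)cc1`, differs from compound 1 in one place: 1-benzothiophen-2-yl in place of 4-methylphenyl on an aromatic carbon. The results so far run from a modest number to the limit, so the step from compound 1 to compound 4 is expected to be small, in either direction, or none beyond the scatter. For compound 4 the expected value is 15000 nM, within 5000 nM to 40000 nM. The step of an at least 1.3-fold lower number from compound 1 to compound 4 (0.12 log units; that floor lies within the scatter) is the one this estimate implies.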

Compound 4, half-maximal inhibitory concentration: 6110 nM
For compound 4 the middle estimate is 2.5-fold (0.39 log units) above the measured one; the range from low to high includes it.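

In this assay, the group on this aromatic carbon of the shared core clearly matters: 1-benzothiophen-2-yl in place of 4-methylphenyl gives an at least 3.2-fold lower number from compound 1 to compound 4 (0.51 log units; beyond the scatter). This is the first readable step among these compounds, and it shows that a larger group with one sulfur atom is accepted at this position. Compound 1 has only a limit, so the full size of the step remains unknown: the limit of > 20000 nM in this assay, at which 2 of the 4 values shown sit.

Whether the sulfur atom or the change in ring makeup accounts for the step stays open. Going by these compounds, how an amine or a carboxylic acid would fare at this position also stays open.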